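Swapping a halogenated phenyl ring on two related cores

The source may report more compounds than this note shows. Statements on the series, on what has been measured and on what is new or still open speak of the compounds shown alone.

Compound 1 `NC1=NC2(CCOCC2)N(OCCCOc2ccccc2Cl)C(N)=N1` carries a 2-chlorophenyl on an oxygen on a saturated carbon. In an assay on isolated protein for inhibition of Dihydrofolate reductase (Homo sapiens), read by spectrophotometry, using NADPH, with stated times of 5 s and 6 min, tested at 5 uM (on this read-out lower numbers stand for a weaker effect and higher numbers for a stronger effect at the one concentration tested), compound 1 gives 83.3%. Compound 2 `NC1=NC2(CCOCC2)N(OCCCOc2cccc(Br)c2)C(N)=N1` differs from compound 1 in a single place, (3-bromophenyl in place of 2-chlorophenyl on an oxygen on a saturated carbon), and in this assay compound 2 gives 86.7%. Measured side by side, this change gave a number 3.4 percentage points higher from compound 1 to compound 2 (within the scatter), so the two values are to be read as equal within the usual scatter.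

Compound 3 `NC1=NC2(CCSCC2)N(OCCCOc2ccccc2Cl)C(N)=N1` carries the same 2-chlorophenyl group on a different core; the difference between the two cores is not broken down here. In this assay compound 3 gives 86.3%, which lies within the scatter of both compound 1 and compound 2.

Compound 4 `NC1=NC2(CCSCC2)N(OCCCOc2cccc(Br)c2)C(N)=N1` has not yet been measured. It differs from compound 3 by 3-bromophenyl in place of 2-chlorophenyl on an oxygen on a saturated carbon, the same change, at the same place, that turns compound 1 into compound 2. Because that earlier occurrence gave a number 3.4 percentage points higher from compound 1 to compound 2 (within the scatter), the step from compound 3 to compound 4 is expected to be of a similar, small size, and the estimate assumes a number 1.7 percentage points higher from compound 3 to compound 4 (within the scatter). This rests on a single measured pair, so the expectation carries the uncertainty of one example. Compound 4 is therefore expected to give about 88%, most likely between 80% and 94%.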

Compound 4, a percentage reported as inhibition, at one concentration (the size of the read-out at that concentration, not a potency): 84.2%
Estimate against measurement, compound 4: 3.8 percentage points above; the measured number falls inside the stated range.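

In this assay, putting 3-bromophenyl in place of 2-chlorophenyl on the core of compound 3 gave a number 2.1 percentage points lower from compound 3 to compound 4 (within the scatter) and so leaves the two values equal for practical purposes. Set beside the same change on the core of compound 1, the new step gives no sign that the choice of core alters the result of this swap: the same change on two cores in this assay, a number 3.4 percentage points higher (within the scatter) from compound 1 to compound 2 and a number 2.1 percentage points lower (within the scatter) from compound 3 to compound 4, 5.5 percentage points apart, within the scatter of two such steps. Going by these compounds alone, this shows only that the change made no step beyond the usual scatter on either of these two cores; it does not show that the two halogenated rings are truly equivalent, since a small real difference could hide in the scatter, and a reading at one concentration is not a potency, so the pairs could still differ at other concentrations or on another core.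

The compounds shown leave open how far the ring can be altered before the read-out moves, for instance with a carboxylic acid or an amine on the phenyl ring in place of the halogen. They also leave open what a longer chain between the core and the phenoxy group would do.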